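This account rests on a few compounds, and the source may have more. Where it says the series, first, only, none or still open, it means among the compounds named here.

Measured so far:
compound 1, `OC1CC2(CCNCC2)Oc2c1ccc1ccccc21`, in a physicochemical assay for lipophilicity, read by HPLC, measured as octanol-water partition, at pH 3 (a lower number here means a more polar compound, a higher number a more lipophilic compound), gives 2.04
compound 2, `CCN1CCC2(CC1)CC(O)c1ccc3ccccc3c1O2`, gives 1.51
compound 3, `CCN1CCC2(CC1)CC(=O)c1ccc3ccccc3c1O2`, gives 1.65

Compound 4, `O=C1CC2(CCNCC2)Oc2c1ccc1ccccc21`, has not yet been measured in this assay. It comes from compound 3 by a single change: hydrogen in place of ethyl on an amine nitrogen in a ring. The same change has already been measured once, from compound 2 to compound 1: hydrogen in place of ethyl on an amine nitrogen in a ring. There it gave a number 0.53 log units higher from compound 2 to compound 1 (beyond the scatter). The place of the change reads the same word for word in both pairs, so it is the same change, not merely the same kind. How the core of compound 2 differs from the core of compound 3 is not broken down here; the two values of compound 2 and compound 3 lie within the usual scatter of each other. Among the compounds with values here, since only one measured example of this change exists, the expectation for compound 4 rests on a number 0.53 log units higher from compound 2 to compound 1 (beyond the scatter) alone, and a step of about a number 0.53 log units higher from compound 3 to compound 4 (beyond the scatter) is expected from compound 3 to compound 4 in this assay. Compound 4 is therefore estimated at 2.18, with a range from 1.85 to 2.55.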

Compound 4, distribution coefficient: 1.48
For compound 4 the middle estimate is 0.70 log units above the measured one; the measured number lies below the stated range.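

In this assay, putting hydrogen in place of ethyl on an amine nitrogen in a ring gave a number 0.53 log units higher from compound 2 to compound 1 (beyond the scatter), whereas the same change on the other core gave a number 0.17 log units lower from compound 3 to compound 4 (within the scatter). One step is therefore beyond the scatter and the other within it, which shows that the size of this step cannot simply be carried from one core to another in this series, even when the change itself is identical. With only these two pairs, the data do not show which result is more typical of the change, and nothing here explains why the two cores part ways.

The compounds shown leave open how other groups on the same ring nitrogen, such as methyl, a longer chain like propyl, or benzyl, would read on either core. They also leave open whether any such group would give steps that match across the two cores.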